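Three Alkyl Variants on One Nitrogen, and a Fourth

A few compounds are considered here, and "the series" means these few. Any claim that something is new, unique, unknown or untested is made for them only; others in the source may bear on it.

Measured compounds in a functional assay on the whole organism (blood, strain Wistar-Okamoto) with Rattus norvegicus as the target, with a stated time of 5 days; a lower number here means that less compound is needed, a higher number that more compound is needed for the effect:
compound 1, `CCCCC/N=C(\NC#N)Nc1cccnc1`, gives 20 mg/kg
compound 2, `CCC(C)/N=C(\NC#N)Nc1cccnc1`, gives 20 mg/kg
compound 3, `N#CN/C(=N\C1CCCC1)Nc1cccnc1`, gives 20 mg/kg

Compound 3 stands level with the other two measured compounds. Its step from compound 1 is no change at the digits printed from compound 1 to compound 3 (within the scatter), and its step from compound 2 is no change at the digits printed from compound 2 to compound 3 (within the scatter); the remaining pair, compound 1 to compound 2, shows no change at the digits printed from compound 1 to compound 2 (within the scatter). All three compounds share one core and differ only in the group carried on a double-bonded nitrogen, and none of those exchanges moved the minimum effective dose beyond the scatter.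

Compound 4, `C=C(C)C/N=C(\NC#N)Nc1cccnc1`, is the next member of this set. It differs from compound 3 as follows: 2-methylprop-2-en-1-yl in place of cyclopentyl on a double-bonded nitrogen. For the measured compounds named here, the steps that bear on this change are the three already described, each an exchange of one small carbon group for another at the same nitrogen, and each without a change beyond the scatter. On that basis compound 4 is expected to behave like its predecessors, with an estimated step of no change at the digits printed from compound 3 to compound 4 (within the scatter) in this assay. The estimated value for compound 4 is therefore 20 mg/kg, with a range from 10 mg/kg to 40 mg/kg.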

Compound 4, minimum effective dose: 20 mg/kg
For compound 4 middle estimate and measured number coincide at the digits printed, within the range that was stated.
By their numbers in this assay, from the lowest: compounds 1, 2, 3 and 4 (each within the scatter of the next).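

In this assay the exchange of the five-membered ring of cyclopentyl for 2-methylprop-2-en-1-yl, an open group with a double bond outside aromatic rings, gives no change at the digits printed from compound 3 to compound 4 (within the scatter) and leaves the minimum effective dose level. The same group in place of sec-butyl gives no change at the digits printed from compound 2 to compound 4 (within the scatter) as its result, and in place of the pentyl group it gives no change at the digits printed from compound 1 to compound 4 (within the scatter) as well. The earlier compounds shown here carried only saturated groups on this double-bonded nitrogen, so the new result adds that an unsaturated carbon group also sits level with an open chain, a branched chain and a carbon ring, and none of the four compounds goes against this.

As far as these compounds go, all four groups are built of carbon alone, so it stays open whether an amine, a carboxylic acid or a much longer chain at this position would also leave the dose level. Nothing shown here gives a reason for the level doses across these groups.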